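The source may report more compounds than this note shows. Statements on the series, on what has been measured and on what is new or still open speak of the compounds shown alone.

Three compounds share one core. Compound 1 `CCCCCCCCS(=O)(=O)Nc1cc(-c2ccccc2Cl)ccc1C(=O)O` gives 26900 nM in an assay on mitochondria (strain BALB/c) for inhibition of glycerol-3-phosphate acyltransferase 1, mitochondrial (Mus musculus), read by scintillation counting, with a stated time of 10 min; a higher number here means a weaker inhibitor, a lower number a stronger inhibitor; compound 2 `CCCCCCCCS(=O)(=O)Nc1cc(-c2ccc(CCCC)cc2)ccc1C(=O)O` gives 15700 nM; compound 3 `CCCCCCCCS(=O)(=O)Nc1cc(-c2ccc(OC)cc2)ccc1C(=O)O` gives 13300 nM. Compound 3 holds the lowest number of the three: its gap to compound 2 lies within the scatter, while the step of a 2.0-fold lower number from compound 1 to compound 3 (0.31 log units; beyond the scatter) is beyond it. Compound 4 `CCCCCCCCS(=O)(=O)Nc1cc(-c2ccccc2F)ccc1C(=O)O` carries 2-fluorophenyl in place of 4-methoxyphenyl on an aromatic carbon. Of the measured steps, the one that bears on this is a 2.0-fold lower number from compound 1 to compound 3 (0.31 log units; beyond the scatter), since compound 4 returns to a 2-halophenyl like compound 1; the step of a 1.7-fold lower number from compound 1 to compound 2 (0.23 log units; within the scatter) adds little. A modest move to a higher number is therefore expected, the expected step being a 1.9-fold higher number from compound 3 to compound 4 (0.27 log units; within the scatter). Compound 4 is estimated at 25000 nM, within 12000 nM to 50000 nM.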

Compound 4, half-maximal inhibitory concentration: 47200 nM
Beside the measured number, compound 4's estimate is 1.9-fold (0.28 log units) below it, within the range that was stated.
By their numbers in this assay, from the lowest: compounds 3, 2, 1 and 4 (each within the scatter of the next, the first and the last beyond it).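

At this position, compound 4 with its 2-fluorophenyl stands apart from both 4-substituted compounds, with a 3.5-fold higher number from compound 3 to compound 4 (0.55 log units; beyond the scatter) and a 3.0-fold higher number from compound 2 to compound 4 (0.48 log units; beyond the scatter), whereas compound 1 was clear only of compound 3. Fluoro in place of chloro does not separate the two 2-halophenyl compounds, with a 1.8-fold higher number from compound 1 to compound 4 (0.24 log units; within the scatter) within the scatter. Nothing available accounts for these gaps. Going by these compounds, whether they follow the group itself or its place on the ring remains open, and a 4-fluorophenyl or 2-methoxyphenyl would separate the two. On these data alone, how an unsubstituted phenyl or an aminophenyl would compare is also open.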